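The source may hold more compounds than are shown below. What is called first, only, known or untested is meant among the compounds shown, and "the series" means these compounds.

Series notes. For the measured compounds named here, compound 1 `O=c1c(CSc2cc(=O)c3ccccc3s2)coc2ccccc12` is the one member with a numerical read-out: in a functional assay on MCF7 cells (Homo sapiens) for cytotoxicity, read by MTT assay, with a stated time of 72 h (on this read-out higher numbers stand for weaker inhibition and lower numbers for stronger inhibition), compound 1 gives 5400 nM. Compound 2 `Cc1nnc(SCc2cc(=O)c3ccccc3o2)s1` does not reach a number in this assay; compound 2 gives > 25000 nM, which is a limit of the assay. Compound 3 `Cc1nnc(SCc2cc(=O)c3cc(Cl)ccc3o2)o1` likewise returns only a limit in this assay, namely > 25000 nM, so its standing among the values shown rests on the limit of > 25000 nM in this assay, at which 2 of the 3 values shown sit, alone. Compound 4 `Cc1nnc(SCc2cc(=O)c3ccccc3o2)o1` is compound 3 after (hydrogen in place of chloro on an aromatic carbon), that is, hydrogen in place of chloro on an aromatic carbon. Going by the values given here, no measured pair calibrates this change; the expected step that the limit leaves unreadable from compound 3 to compound 4 is within the scatter. Compound 4 is accordingly expected to return 30000 nM, most likely again a limit, within 12000 nM to 80000 nM.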

Compound 4, half-maximal inhibitory concentration: > 25000 nM
Compound 4: no number, only a limit (the forecaster's own chance of this, stated with the estimate: 75%); the middle value does not contradict the limit.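

Compound 2, compound 3 and compound 4 each return only a limit in this assay, so neither step into compound 4 can be read: the limit of > 25000 nM in this assay, at which 3 of the 4 values shown sit.

The compounds shown leave open whether hydrogen in place of chloro, or 5-methyl-1,3,4-oxadiazol-2-yl in place of 5-methyl-1,3,4-thiadiazol-2-yl, shifts the read-out at all.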